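This account rests on a few compounds, and the source may have more. Where it says the series, first, only, none or still open, it means among the compounds named here.

Measured compounds in a functional assay on HT-29 cells (Homo sapiens) for cytotoxicity, read by MTT assay, with a stated time of 72 h; a higher number here means a weaker inhibitor of growth, a lower number a stronger inhibitor of growth:

compound 1, `CS/C(=N\C(=O)c1ccco1)NC(=O)c1ccco1`, gives > 100000 nM, which is a limit of the assay and not a number.
compound 2, `O=C(/N=C(/NC(=O)c1cccs1)[Se]Cc1ccccc1)c1cccs1`, gives > 100000 nM, again a limit and not a number.
compound 3, `CS/C(=N\C(=O)c1cccs1)NC(=O)c1cccs1`, gives > 100000 nM, also a limit and not a number.

The core of compound 1 and the core of compound 3 differ, but the difference between the two cores is not broken down here. Compound 2 arises from compound 3 by a group of 8 heavy atoms (7 carbon, 1 selenium; one six-membered aromatic ring of carbon only) in place of a group of 2 heavy atoms (1 carbon, 1 sulfur; no ring), on a carbon with a double bond to nitrogen. The step that the two limits leave unreadable from compound 3 to compound 2 cannot be read because of the limit of > 100000 nM in this assay, at which 3 of the 3 values shown sit, so it gives no size for this change.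

Compound 4, `O=C(/N=C(/NC(=O)c1ccco1)[Se]Cc1ccccc1)c1ccco1`, is not yet measured in this assay. It arises from compound 1 by a group of 8 heavy atoms (7 carbon, 1 selenium; one six-membered aromatic ring of carbon only) in place of a group of 2 heavy atoms (1 carbon, 1 sulfur; no ring), on a carbon with a double bond to nitrogen, the same change as from compound 3 to compound 2, at a place described in the same words.

Within the data shown here, the expectation for compound 4 rests only on the fact that (the limit of > 100000 nM in this assay, at which 3 of the 3 values shown sit), and that the one earlier instance of this change, from compound 3 to compound 2, gave no readable size. Compound 4 is therefore expected to sit at or near the same limit, with an expected step that the limit leaves unreadable from compound 1 to compound 4 that is itself unreadable in size. For compound 4 the estimate in this assay is 150000 nM, with a plausible range from 50000 nM to 500000 nM, and most likely the assay will report only a limit and no number.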

Compound 4, concentration for total growth inhibition: 89100 nM
Estimate against measurement, compound 4: 1.7-fold (0.23 log units) above, and the stated range covers the measured number.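

In this assay, methylsulfanyl leaving and the group of 8 heavy atoms with one six-membered aromatic ring of carbon only entering, on a carbon with a double bond to nitrogen, gives an at least 1.1-fold lower number from compound 1 to compound 4 (0.05 log units; that floor lies within the scatter), so on the core of compound 1 even the smallest step the data allow cannot be told from scatter. Compound 1 gives > 100000 nM, which is a limit and not a number. The true size of this step remains unknown, the matching step on the core of compound 3 cannot be read, and whether the change carries from one core to the other cannot be decided, because so many values rest on the ceiling: the limit of > 100000 nM in this assay, at which 3 of the 4 values shown sit.

The compounds shown leave open how far the selenium and the six-membered aromatic ring each count in this change, a question that a sulfur-linked group carrying the same ring, or a selenium-linked methyl group, would address in this assay. Also open, on these data alone, is what an amine or a carboxylic acid on that ring, or a longer chain in its place, would do to growth inhibition on either core.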